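This account rests on a few compounds, and the source may have more. Where it says the series, first, only, none or still open, it means among the compounds named here.

Measured compounds:
compound 1 `N#Cc1ccc(Nc2nccc(Oc3ccc(OCc4ccccc4)cc3)n2)cc1`, > 316000 nM
compound 2 `Cc1cc(Oc2ccc(C(=O)c3ccc(O)cc3)cc2)nc(Nc2ccc(C#N)cc2)n1`, 32000 nM

Both were tested in an ADME assay on MT4 cells (Homo sapiens) for cytotoxicity, read by MTT assay, with a stated time of 5 days; on this read-out higher numbers stand for lower toxicity in this test and lower numbers for higher toxicity in this test. Among the measured compounds shown here, compound 2 gives 32000 nM, and this is the only actual number in the set. For compound 1 the read-out is a limit of the assay and not a number: compound 1 gives > 316000 nM, which is the limit of > 316000 nM in this assay, at which 1 of the 2 values shown sits. For the measured compounds named here, compound 2 therefore stands as the sole measured value here, with the other result sitting at the edge of what the test can report.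

Compound 3 `Cc1cc(Oc2ccc(OCc3ccccc3)cc2)nc(Nc2ccc(C#N)cc2)n1` has not yet been measured. It differs from compound 2 in one place: benzyloxy in place of (4-hydroxyphenyl)carbonyl on an aromatic carbon. Going by the values given here, no step between two measured compounds is available, so the size of the change cannot be read from a measured pair and can only be expected. The expected step is a 5.6-fold higher number from compound 2 to compound 3 (0.75 log units; beyond the scatter), in the direction of lower toxicity in this assay. Compound 3 is estimated at 180000 nM, within a range from 60000 nM to 400000 nM, with a real chance that the assay reports only a limit.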

Compound 3, half-maximal cytotoxic concentration: 27700 nM
Beside the measured number, compound 3's estimate is 6.5-fold (0.81 log units) above it; measured number below the stated range.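

Exchanging (4-hydroxyphenyl)carbonyl for benzyloxy on this aromatic carbon, para to a large group, gives in this assay a 1.2-fold lower number from compound 2 to compound 3 (0.06 log units; within the scatter), so the read-out does not separate these two groups, although the donor and the double bond outside aromatic rings leave with the first and both groups carry one six-membered aromatic ring of carbon only. With benzyloxy held in place, methyl in place of hydrogen on an aromatic carbon gives a clear difference, an at least 11-fold lower number from compound 1 to compound 3 (1.05 log units; beyond the scatter), so among the compounds shown the step beyond the scatter lies at that methyl and not at the benzyloxy position. That step starts from compound 1, whose read-out is a limit and not a number: the limit of > 316000 nM in this assay, at which 1 of the 3 values shown sits.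

Among the compounds shown here, what stays open is whether methyl in place of hydrogen gives a step of similar size with (4-hydroxyphenyl)carbonyl in the other place, as the one pair for that change carries benzyloxy. Also open, on these data alone, is how the read-out responds when a group without an aromatic ring, such as an amine or a carboxylic acid, stands on that aromatic carbon, or when a longer chain such as ethyl takes the place of the methyl.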